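Notes on the step from compound 3 to compound 4

A few compounds are considered here, and "the series" means these few. Any claim that something is new, unique, unknown or untested is made for them only; others in the source may bear on it.

Values so far in a functional assay on A549 cells (Homo sapiens), read by MTT assay, with a stated time of 72 h; on this read-out lower numbers stand for stronger inhibition and higher numbers for weaker inhibition
- compound 1 `COc1ncnc2c1c(-c1ccccc1)cn2[C@@H]1O[C@H](CO)[C@@H](O)[C@H]1O` gives > 20000 nM (a limit of the assay)
- compound 2 `COc1ncnc2c1c(-c1cc3ccccc3o1)cn2[C@@H]1O[C@H](CO)[C@@H](O)[C@H]1O` gives 17700 nM
- compound 3 `C#Cc1cn([C@@H]2O[C@H](CO)[C@@H](O)[C@H]2O)c2ncnc(SC)c12` gives 140 nM

Compound 3 has the lowest of the two actual numbers and lies beyond the scatter from compound 2, its nearest neighbour. The entry for compound 1 is only a limit.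

Compound 4 `C#Cc1cn([C@@H]2O[C@H](CO)[C@@H](O)[C@H]2O)c2ncnc(NC)c12` is still unmeasured. It differs from compound 3 by methylamino in place of methylsulfanyl on an aromatic carbon. Within the data shown here, the one measured step, an at least 1.1-fold lower number from compound 1 to compound 2 (0.05 log units; that floor lies within the scatter) (a different group), has a floor within the scatter and gives no size for this exchange. Among the measured compounds shown here, no measured pair tests the exchange directly, so the range stays wide. The starting point is compound 3 at 140 nM and a moderately higher number is expected, although a lower one cannot be ruled out. The expected step is a 2.1-fold higher number from compound 3 to compound 4 (0.33 log units; beyond the scatter) in this assay on this basis. Compound 4 is estimated at 300 nM (expected range 50 nM to 2500 nM).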

Compound 4, half-maximal inhibitory concentration: > 20000 nM
Compound 4: a limit, no number; the forecaster's own chance of this, stated with the estimate: 5%; middle value at least 66-fold (1.82 log units) from the limit.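

In this assay, methylamino in place of methylsulfanyl on the aromatic carbon next to the ring nitrogen gives an at least 140-fold higher number from compound 3 to compound 4 (2.15 log units; beyond the scatter). Among these compounds, this is the only measured pair that isolates this position, and it shows that the shared core does not tolerate every small group there: the exchange puts nitrogen for sulfur and brings in a hydrogen-bond donor, yet the activity of compound 3 is not retained. Compound 4 reads as a limit of the assay, not a number: the limit of > 20000 nM in this assay, at which 2 of the 4 values shown sit.

The compounds shown leave open whether the step follows the loss of sulfur or the entry of the donor; dimethylamino on this carbon would separate the two. Ethylsulfanyl there would show whether a longer chain keeps the activity, and methoxy occurs only in compound 1 and compound 2, which differ from compound 3 in a second place.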